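Pyrazole carboxylic acids on a thiazole core: aryl variation

The source may report more compounds than this note shows. Statements on the series, on what has been measured and on what is new or still open speak of the compounds shown alone.

Measured so far:
compound 1 `Cc1nn(-c2nc(-c3ccc(Cl)c(Cl)c3)c(SC(C)C)s2)c(C(=O)O)c1-c1ccc(Cl)cc1`: 2500 nM
compound 2 `Cc1c(-c2cc(Cl)cc(Cl)c2)c(C(=O)O)nn1-c1nc(-c2ccncc2)c(SC(C)C)s1`: "not active" (no number reported)
compound 3 `COC(=O)c1c(Cc2ccccc2[N+](=O)[O-])c(C)nn1-c1nc(-c2ccc(Cl)c(Cl)c2)c(SC(C)C)s1`: 93000 nM

In a functional assay on BJAB cells (Homo sapiens) for antiproliferative activity, with a stated time of 4 days (on this read-out lower numbers stand for an effect already at smaller amounts and higher numbers for an effect only at larger amounts of compound), compound 1 stands at the lowest of the two reported numbers; compound 3 sits far higher, beyond the scatter, and compound 2 is reported without a number. No pair among these compounds differs in a single place, so no measured step is available to guide the next change. Compound 4 `CCOc1ncccc1-c1c(C)nn(-c2nc(-c3ccc(Cl)c(Cl)c3)c(SC(C)C)s2)c1C(=O)O` differs from compound 1 as follows: 2-ethoxypyridin-3-yl in place of 4-chlorophenyl on an aromatic carbon. Going by the values given here, with no comparable step in hand, a modest weakening or no change beyond the scatter is expected in this assay, so the step of a 1.6-fold higher number from compound 1 to compound 4 (0.20 log units; within the scatter) is estimated to be small. For compound 4 the expected value in this assay is 4000 nM, within 800 nM to 20000 nM.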

Compound 4, half-maximal effective concentration: 11000 nM
Estimate against measurement, compound 4: 2.8-fold (0.44 log units) below; measured number inside the range.
By their numbers in this assay, from the lowest: compound 1; then compound 4; then compound 3.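

In this assay this position now has its first measured single-place step: 2-ethoxypyridin-3-yl in place of 4-chlorophenyl gives a 4.4-fold higher number from compound 1 to compound 4 (0.64 log units; beyond the scatter). The aromatic carbon next to the ring atom bearing the carboxy group therefore responds to the aryl group it carries, and the change still leaves a reported number. Nothing measured here explains the step.

The compounds shown do not separate the contribution of the ring nitrogen from that of the ethoxy group. A 2-ethoxyphenyl or an unsubstituted pyridin-3-yl group at this position would address that question.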